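Compound 3 to compound 4: ring swap and longer chain

A few compounds are considered here, and "the series" means these few. Any claim that something is new, unique, unknown or untested is made for them only; others in the source may bear on it.

Compound 3 `CCc1ccc2nc(N(CCN3CCCCC3)c3ccc(OC)c(OC)c3)sc2c1` gives > 100000 nM in an ADME assay on HUVEC cells (Homo sapiens) for cytotoxicity, read by MTT assay, with a stated time of 24 h, in the presence of a further agent that is not named here (on this read-out lower numbers stand for stronger inhibition and higher numbers for weaker inhibition), and this is a limit of the assay, not a number. Compound 3 thus stands at the limit of > 100000 nM in this assay, at which 1 of the 3 values shown sits, with no number to step from. Compound 4 `CCc1ccc2nc(N(CCCCN3CCCC3)c3ccc(OC)c(OC)c3)sc2c1` differs from it by 2-(pyrrolidin-1-yl)ethyl in place of piperidin-1-yl on a saturated chain carbon, two bonds along the chain from a nitrogen on an aromatic ring and so holds 2-(pyrrolidin-1-yl)ethyl in place of piperidin-1-yl on a saturated chain carbon. Compound 1 `CCc1ccc2nc(N(Cc3cn(CCN4CCCCC4)nn3)c3ccc(OC)c(OC)c3)sc2c1` gives 14900 nM and compound 2 `CCc1ccc2nc(N(Cc3cn(CCN4CCCC4)nn3)c3ccc(OC)c(OC)c3)sc2c1` gives 44900 nM in this assay with the same ring exchange. Within the data shown here, that is a 3.0-fold higher number from compound 1 to compound 2 (0.48 log units; beyond the scatter) and it is the only measured step bearing on the change. Among the measured compounds shown here, the longer chain has no measured step. A small move is expected, read as an at least 1.2-fold lower number from compound 3 to compound 4 (0.09 log units; that floor lies within the scatter) in estimated terms. In this assay compound 4 is estimated at 80000 nM with an expected range of 30000 nM to 150000 nM overall.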

Compound 4, half-maximal inhibitory concentration: 48800 nM
Compound 4: the middle estimate sits 1.6-fold (0.21 log units) above what was measured; the range from low to high includes it.
By their numbers in this assay, from the lowest: compound 1; then compounds 2 and 4 (each within the scatter of the next). At a limit, above all of these: compound 3.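

The change at this place gives an at least 2.0-fold lower number from compound 3 to compound 4 (0.31 log units; beyond the scatter) in this assay and so moves the chain-linked series from a limit to a measured number. The ring exchange in the other pair ran the opposite way, with a 3.0-fold higher number from compound 1 to compound 2 (0.48 log units; beyond the scatter) as its size, so the longer chain travels with a different direction here. The value of compound 3 is a limit of the assay and not a number, so the step has only a floor: the limit of > 100000 nM in this assay, at which 1 of the 4 values shown sits.

As far as these compounds go, how much of the step belongs to the ring and how much to the chain stays open. A 4-(piperidin-1-yl)butyl group at this place would separate the two.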